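Removing one trifluoromethyl from a diaryl urea

This account rests on a few compounds, and the source may have more. Where it says the series, first, only, none or still open, it means among the compounds named here.

Compound 1: `O=C(Nc1cccc(-n2cc(-c3ccncc3)c(-c3cc(O)cc(Cl)c3)n2)c1)Nc1ccc(Cl)c(C(F)(F)F)c1`, 92%
Compound 2: `COc1cc(Cl)cc(-c2nn(-c3cccc(NC(=O)Nc4cc(C(F)(F)F)cc(C(F)(F)F)c4)c3)cc2-c2ccncc2)c1`, 94%

Two compounds share a core and differ in the groups around the urea. In a functional assay on NCI-H23 cells (Homo sapiens) for inhibition, read by sulforhodamine B assay, with a stated time of 48 h, tested at 0.01 uM (a higher number here means a weaker effect of the compound at the concentration tested, a lower number a stronger effect), compound 1 gives 92%, and in this assay compound 2 gives 94%. Of the two numbers, that of compound 2 is the higher, but its gap to compound 1 lies within the usual scatter, so the two cannot be told apart: both leave most of the cell signal intact at this concentration.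

Compound 3 is `COc1cc(Cl)cc(-c2nn(-c3cccc(NC(=O)Nc4cccc(C(F)(F)F)c4)c3)cc2-c2ccncc2)c1`. It differs from compound 2 in one place: hydrogen in place of trifluoromethyl on an aromatic carbon. Going by the values given here, no step between measured compounds is available for this change, so the expectation rests on the two numbers alone. Because compound 2 gives 94%, an already weak effect, the step from compound 2 to compound 3 is expected to be a number 1 percentage points higher from compound 2 to compound 3 (within the scatter), none beyond the scatter. Compound 3 is estimated at 95%, with a range from 85% to 105%.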

Compound 3, a percentage reported as activity, at one concentration (the size of the read-out at that concentration, not a potency): 97%
Compound 3: middle estimate off by 2 percentage points, on the low side, and the stated range covers the measured number.
By their numbers in this assay, from the lowest: compounds 1, 2 and 3 (each within the scatter of the next).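

In this assay, replacing the trifluoromethyl with hydrogen gives a number 3 percentage points higher from compound 2 to compound 3 (within the scatter), so this change cannot be told apart from the ordinary spread of repeat measurements. Compound 2 and compound 3 are the first pair shown that differ in one place only, which allows this single change to be read by itself, free of the other differences between compound 1 and compound 2. Both compounds leave most of the cell signal intact at this one low concentration, so the result shows no effect of the change under these conditions, and it cannot show how the change would behave where the compounds act more strongly.

On these data alone, whether an amine or a carboxylic acid at this place would give a different number remains open. Nothing shown here offers an explanation for the result.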